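Aryl swap on the hydroxyalkyl chain: compound 2 to compound 4

The source may report more compounds than this note shows. Statements on the series, on what has been measured and on what is new or still open speak of the compounds shown alone.

Compound 1 `C[C@@H](O)CCn1nc2c(Br)c(Br)c(Br)c(Br)c2n1`: 18%
Compound 2 `OC(CCn1nc2c(Br)c(Br)c(Br)c(Br)c2n1)c1cccc(Cl)c1`: 0%
Compound 3 `C[C@H](O)CCn1nc2c(Br)c(Br)c(Br)c(Br)c2n1`: 31%

In a functional assay on MCF7 cells (Homo sapiens) for antiproliferative activity, read by MTT assay, with a stated time of 24 h, tested at 100 uM (a higher number here means a weaker effect of the compound at the concentration tested, a lower number a stronger effect), compound 2 gives the lowest of the three numbers, with compound 1 nearest and compound 3 furthest, both beyond the scatter. Compound 4 `OC(CCn1nc2c(Br)c(Br)c(Br)c(Br)c2n1)c1ccc(F)cc1` differs from compound 2 by 4-fluorophenyl in place of 3-chlorophenyl on a saturated chain carbon bound to an oxygen on a saturated carbon and a saturated chain carbon. Within the data shown here, the only measured step, a number 13 percentage points higher from compound 1 to compound 3 (beyond the scatter), rests on the fact that compounds 1 and 3 differ only in the configuration as drawn and says nothing about the aryl group, so no measured step bears directly on this change. The expectation is therefore a step within the scatter, a number 8 percentage points higher from compound 2 to compound 4 (within the scatter), with compound 4 staying close to compound 2. The estimate for compound 4 is 8%, in a range from 0% to 25%.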

Compound 4, a percentage reported as activity, at one concentration (the size of the read-out at that concentration, not a potency): 0%
Beside the measured number, compound 4's estimate is 8 percentage points above it; the range from low to high includes it.
By their numbers in this assay, from the lowest: compounds 2 and 4 (each within the scatter of the next); then compound 1; then compound 3.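

In this assay, replacing 3-chlorophenyl with 4-fluorophenyl on this chain carbon gives no change at the digits printed from compound 2 to compound 4 (within the scatter), so the low reading of compound 2 is not tied to 3-chlorophenyl alone. The halogen and its place on the ring change together here, so their separate contributions cannot be told apart. Among these compounds, nothing measured so far explains why this swap leaves the reading unchanged.

Going by these compounds, it remains open whether the ring needs a halogen at all, as plain phenyl or a methoxy-bearing phenyl would show. A pyridine ring at this carbon is equally unexplored.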